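The compounds below may be only part of what the source reports. "The series", "measured", "known", "first", "only" and "open" are said of these compounds alone.

Measured compounds in an assay on CHO cells for displacement of a labelled ligand from Substance-P receptor (Homo sapiens), in the presence of a further agent that is not named here; a lower number here means a stronger inhibitor, a higher number a weaker inhibitor:
- compound 1, `C[C@@H](O[C@H]1CN2C(=O)C=C(c3cc[n+]([O-])cc3)CC2[C@@H]1c1ccc(F)cc1)c1cc(C(F)(F)F)cc(C(F)(F)F)c1`, with compound 1 giving 2.1 nM
- compound 2, `Cc1cc(C2=CC(=O)N3C[C@H](O[C@H](C)c4cc(C(F)(F)F)cc(C(F)(F)F)c4)[C@@H](c4ccc(F)cc4)C3C2)ccn1`, with compound 2 giving 34 nM
- compound 3, `CCc1noc(C2=CC(=O)N3C[C@H](O[C@H](C)c4cc(C(F)(F)F)cc(C(F)(F)F)c4)[C@@H](c4ccc(F)cc4)C3C2)n1`, with compound 3 giving 27 nM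

Compound 3 stands second highest of the three numbers in this assay. Its nearest neighbour is compound 2, the pair differing by a 1.3-fold lower number from compound 2 to compound 3 (0.10 log units; within the scatter), a gap within the scatter, so no order between them can be read. Compound 1 stands furthest away, the gap being a 13-fold higher number from compound 1 to compound 3 (1.11 log units; beyond the scatter).

The unmeasured compound 4 is `C[C@@H](O[C@H]1CN2C(=O)C=C(C3=CCC(O)CC3)CC2[C@@H]1c1ccc(F)cc1)c1cc(C(F)(F)F)cc(C(F)(F)F)c1`. It differs from compound 3 in one place: 4-hydroxycyclohex-1-en-1-yl in place of 3-ethyl-1,2,4-oxadiazol-5-yl on a double-bonded ring carbon.

Among the compounds with values here, two measured steps touch the same place. Exchanging the group on that double-bonded ring carbon gave a 16-fold higher number from compound 1 to compound 2 (1.21 log units; beyond the scatter) and a 13-fold higher number from compound 1 to compound 3 (1.11 log units; beyond the scatter), both large, while the exchange between two different aromatic groups gave a 1.3-fold lower number from compound 2 to compound 3 (0.10 log units; within the scatter), within the scatter. Within the data shown here, no measured step brings in a non-aromatic ring or a hydrogen-bond donor at this place, so the direction for compound 4 in this assay rests on thin ground. Given that compound 2 and compound 3 sit close together, a step of about a 1.2-fold lower number from compound 3 to compound 4 (0.09 log units; within the scatter) is expected, that is no change beyond the scatter.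

Compound 4 is therefore estimated at 22 nM, with a range from 5 nM to 90 nM.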

Compound 4, half-maximal inhibitory concentration: 13 nM
For compound 4 the middle estimate is 1.7-fold (0.23 log units) above the measured one; the measured number falls inside the stated range.
By their numbers in this assay, from the lowest: compound 1; then compound 4; then compounds 3 and 2 (each within the scatter of the next).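

In this assay, within the data shown here, the position does not depend on an aromatic ring: 4-hydroxycyclohex-1-en-1-yl, the first group here with a non-aromatic ring of carbon only and a hydrogen-bond donor at this double-bonded ring carbon, gives a 2.1-fold lower number from compound 3 to compound 4 (0.32 log units; beyond the scatter) and a 2.6-fold lower number from compound 2 to compound 4 (0.42 log units; beyond the scatter) as modest steps beyond the scatter, whereas compound 2 and compound 3 could not be told apart. The new group does not close the gap to the best compound, however, as a 6.2-fold higher number from compound 1 to compound 4 (0.79 log units; beyond the scatter) leaves compound 1 the lowest number of the four. No supporting measurement is available to explain these steps.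

Still open, as far as these compounds go, is whether the gain over compound 2 and compound 3 belongs to the hydroxyl or to the carbon ring that carries it, and an unsubstituted cyclohexenyl ring, or an amine or a carboxylic acid in place of the hydroxyl, would separate the two. From the compounds shown here alone, it is equally open whether a fully saturated cyclohexyl ring would keep the number of compound 4 or lose it, so the role of the ring double bond cannot be judged from these compounds.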